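Flipping the Single Stereocentre of a Carboxylic Acid Agonist

This account rests on a few compounds, and the source may have more. Where it says the series, first, only, none or still open, it means among the compounds named here.

Compound 2 `O=C(O)CC[C@H]1CCc2cc(-c3cc(OC(F)(F)F)ccc3F)ccc2O1` carries a carboxy group on a saturated chain two bonds from a saturated ring carbon. For the measured compounds named here, in a functional assay on HEK293 cells for agonist activity at Free fatty acid receptor 1 (Homo sapiens), read by HTRF and inositol phosphate accumulation, with a stated time of 60 min (a lower number here means that less compound is needed, a higher number that more compound is needed for the effect), compound 2 gives 2100 nM, the only plain number among the values shown. Compound 1 `Fc1ccc(OC(F)(F)F)cc1-c1ccc2c(c1)CC[C@H](CCc1nnn[nH]1)O2` has the same skeleton with a 1H-tetrazol-5-yl group in place of the carboxy. For compound 1 the result in this assay is a limit of the assay, > 10000 nM. Going by the values given here, the only measured step, an at least 4.7-fold lower number from compound 1 to compound 2 (0.67 log units; beyond the scatter), exchanges one group for another and says nothing about configuration. Compound 3 `O=C(O)CC[C@@H]1CCc2cc(-c3cc(OC(F)(F)F)ccc3F)ccc2O1` differs from compound 2 only in its drawn configuration: the two compounds have the same atoms and bonds and differ only in configuration as drawn: 1 of 1 stereo elements differ; a stereocentre at a saturated ring carbon is drawn R in compound 2 and S in compound 3. No measured pair bears on such a change, so its direction cannot be read from the numbers shown. Compound 3 is therefore expected near 4500 nM, with a wide range from 900 nM to 20000 nM. That estimate means an expected step of a 2.1-fold higher number from compound 2 to compound 3 (0.33 log units; beyond the scatter).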

Compound 3, half-maximal effective concentration: > 10000 nM
Compound 3: only a limit was reported (the forecaster's own chance of this, stated with the estimate: 35%); middle value at least 2.2-fold (0.34 log units) from the limit.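

Turning the stereocentre at this saturated ring carbon from R in the drawing to S gives an at least 4.7-fold higher number from compound 2 to compound 3 (0.67 log units; beyond the scatter) in this assay, so the carboxy group alone does not secure the result and the configuration at this carbon counts too. The shift can be put down to configuration alone, something the earlier exchange of groups could not show, because nothing else separates the pair: the fact that compounds 2 and 3 differ only in the configuration as drawn. Compound 3 gives > 10000 nM, which is a limit of the assay and not a number, so the true size of the step remains unknown: the limit of > 10000 nM in this assay, at which 2 of the 3 values shown sit.

Going by these compounds, it remains open whether the R drawing would also give the lower number with a 1H-tetrazol-5-yl group on the chain. On these data alone, it is equally open whether this configuration would still give the lower number with a longer chain or with an amide in place of the carboxylic acid.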